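Chloro on the pendant phenyl across two cores

The compounds below may be only part of what the source reports. "The series", "measured", "known", "first", "only" and "open" are said of these compounds alone.

Compound 1 `FC(F)(F)c1ccc(C2CC(c3ccccc3)=NN2c2ccc(-c3ccccc3)nn2)cc1` is the reference point in a functional assay on A549 cells (Homo sapiens) for antiproliferative activity, read by MTT assay, with a stated time of 24 h (a higher number here means a weaker inhibitor, a lower number a stronger inhibitor), where compound 1 gives 9160 nM. Compound 2 `FC(F)(F)c1ccc(C2CC(c3ccc(Cl)cc3)=NN2c2ccc(-c3ccccc3)nn2)cc1` carries chloro in place of hydrogen on an aromatic carbon. In this assay compound 2 returns only a limit, > 100000 nM, not a number. The step of an at least 10-fold higher number from compound 1 to compound 2 (1.03 log units; beyond the scatter) therefore rests on the limit of > 100000 nM in this assay, at which 1 of the 3 values shown sits, and marks a floor, not a measured size. Compound 3 `COc1ccc(C2=NN(c3ccc(-c4ccccc4)nn3)C(c3ccccc3)C2)cc1` has another core; the difference between the two cores is not broken down here. In this assay compound 3 gives 75900 nM, the higher of the two numbers, beyond the scatter from compound 1. Compound 4 `COc1ccc(C2=NN(c3ccc(-c4ccccc4)nn3)C(c3ccc(Cl)cc3)C2)cc1` is not yet measured; it differs from compound 3 by chloro in place of hydrogen on an aromatic carbon, the same change as from compound 1 to compound 2, at a place described in the same words. Expected is a step of a 3.3-fold higher number from compound 3 to compound 4 (0.52 log units; beyond the scatter) because an at least 10-fold higher number from compound 1 to compound 2 (1.03 log units; beyond the scatter) was large and reached the limit. Compound 3 already starts high. Compound 4 is estimated at 250000 nM, most likely reported only as a limit.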

Compound 4, half-maximal inhibitory concentration: 100000 nM
Compound 4: the middle estimate sits 2.5-fold (0.40 log units) above what was measured; the range from low to high includes it.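

In this assay, the change from phenyl to 4-chlorophenyl gives a 1.3-fold higher number from compound 3 to compound 4 (0.12 log units; within the scatter), so the large step on the core of compound 1 does not carry over in size: the same change on two cores in this assay, an at least 10-fold higher number (1.03 log units; beyond the scatter) from compound 1 to compound 2 and a 1.3-fold higher number (0.12 log units; within the scatter) from compound 3 to compound 4, at least 8.2-fold (0.91 log units) apart, beyond the scatter of two such steps. Compound 2 gives only a limit, > 100000 nM, so the step to compound 2 and the gap between the two steps are floors, not measured sizes: the limit of > 100000 nM in this assay, at which 1 of the 4 values shown sits. Two pairs do not show whether the gap comes from the rest of the core or from which phenyl takes the chloro, and they say nothing about any further core.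

Open, as far as these compounds go, is how a group other than chloro behaves at this place on either core, for instance an amine or a carboxylic acid. Also open, from the compounds shown here alone, is whether a fluoro on the two cores would give the same gap, with steps that can be read as numbers on both.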